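Replacing the chain end of compound 3 with a diethylamino group

This account rests on a few compounds, and the source may have more. Where it says the series, first, only, none or still open, it means among the compounds named here.

Measured compounds:
- compound 1, `CCOc1c(-c2cc(OC)c(OC)c(OC)c2)oc2ccccc2c1=O`: 6200 nM
- compound 2, `CCCOc1c(-c2cc(OC)c(OC)c(OC)c2)oc2ccccc2c1=O`: 2800 nM
- compound 3, `CCCCCCCOc1c(-c2cc(OC)c(OC)c(OC)c2)oc2ccccc2c1=O`: > 50000 nM

All three share one core and differ only in the chain attached through an oxygen on an aromatic ring. In a functional assay on DU-145 cells (Homo sapiens) for antiproliferative activity, read by WST assay, with a stated time of 3 days (a lower number here means a stronger inhibitor, a higher number a weaker inhibitor), compound 1 gives 6200 nM. Compound 2 gives 2800 nM, a step of a 2.2-fold lower number from compound 1 to compound 2 (0.35 log units; beyond the scatter). For compound 3 the result is > 50000 nM, which is a limit of the assay and not a number, so compound 3 stands at the weak end of the three, with the limit of > 50000 nM in this assay, at which 1 of the 3 values shown sits, marking where its value sits. The steps into compound 3 are an at least 8.0-fold higher number from compound 1 to compound 3 (0.90 log units; beyond the scatter) and an at least 17-fold higher number from compound 2 to compound 3 (1.25 log units; beyond the scatter).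

Compound 4, `CCN(CC)CCCCCOc1c(-c2cc(OC)c(OC)c(OC)c2)oc2ccccc2c1=O`, differs from compound 3 by diethylamino in place of ethyl on a saturated chain carbon, five bonds along the chain from an oxygen on an aromatic ring. Among the compounds with values here, the two steps that lengthened the chain both gave higher numbers, but none of the measured steps introduces a nitrogen, so they bear on compound 4 only loosely. The estimate for compound 4 is therefore wide: it is expected at 15000 nM, in a range from 2000 nM to 100000 nM. The expected step is an at least 3.3-fold lower number from compound 3 to compound 4 (0.52 log units; beyond the scatter), and a result that is again only a limit would not be surprising.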

Compound 4, half-maximal inhibitory concentration: 33400 nM
For compound 4 the middle estimate is 2.2-fold (0.35 log units) below the measured one; measured number inside the range.
By their numbers in this assay, from the lowest: compound 2; then compound 1; then compound 4. At a limit, above all of these: compound 3.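

Of the compounds shown, only compound 4 carries a nitrogen in its chain, and with diethylamino in place of ethyl, in this assay compound 4 gives 33400 nM, a measured number. Compound 3 stands at a limit of the assay and not at a number: the limit of > 50000 nM in this assay, at which 1 of the 4 values shown sits.
The step between these two is therefore only a floor, an at least 1.4-fold lower number from compound 3 to compound 4 (0.17 log units; that floor lies within the scatter), so it cannot show that the swap changes the result, while the long chain with its amine still lies on the weak side of the two short chains, with a 12-fold higher number from compound 2 to compound 4 (1.08 log units; beyond the scatter) and a 5.4-fold higher number from compound 1 to compound 4 (0.73 log units; beyond the scatter).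

Still open, as far as these compounds go, is whether a shorter chain carrying the same amine, or a ring amine such as piperidine or morpholine at the end of the chain, would come closer to the numbers of compound 1 and compound 2. Chains of intermediate length, such as butyl or pentyl on the same oxygen, also remain open, so where along the chain the numbers begin to climb cannot yet be told.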